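A few compounds are considered here, and "the series" means these few. Any claim that something is new, unique, unknown or untested is made for them only; others in the source may bear on it.

Measured so far in an assay on isolated protein for inhibition of Bile acid receptor (Homo sapiens), read by TR-FRET and LanthaScreen; a lower number here means a stronger inhibitor, a higher number a weaker inhibitor:

compound 1 `CC(C)C[C@@H](c1nc2ccc(C(=O)O)cc2n1C)N1C(=O)CN(c2ccc(Oc3ccccc3)cc2)C1=O`: 43400 nM
compound 2 `Cn1c([C@H](CC2CCCCC2)N2C(=O)CN(c3ccc(Oc4ccccc4)cc3)C2=O)nc2ccc(C(=O)O)cc21`: 24400 nM
compound 3 `CC[C@@H](c1nc2ccc(C(=O)O)cc2n1C)N1C(=O)CN(c2ccc(Oc3ccccc3)cc2)C1=O`: 210000 nM

Compound 1 stands second highest of the three numbers. Its nearest neighbour is compound 2, reached by a 1.8-fold lower number from compound 1 to compound 2 (0.25 log units; within the scatter), a step within the scatter, so the two cannot be ordered. Compound 3 lies furthest off, by a 4.8-fold higher number from compound 1 to compound 3 (0.68 log units; beyond the scatter), and the same direction shows from compound 2 by an 8.6-fold higher number from compound 2 to compound 3 (0.93 log units; beyond the scatter). All three of these steps concern one place only, the saturated chain carbon two bonds from the ring amide nitrogen and the aromatic carbon; nothing measured touches the phenoxy end of the shared core.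

Compound 4 `COc1ccc(Oc2ccc(N3CC(=O)N([C@@H](CC(C)C)c4nc5ccc(C(=O)O)cc5n4C)C3=O)cc2)cc1` differs from compound 1 in exactly that untested region: methoxy in place of hydrogen on an aromatic carbon. Within the data shown here, no measured step bears on this change, so there is no basis for a direction; the working expectation is a step no larger than the scatter, a 1.1-fold lower number from compound 1 to compound 4 (0.04 log units; within the scatter). On these data alone, compound 4 is therefore expected to give about 40000 nM in this assay, with a range of roughly 15000 nM to 110000 nM, the width reflecting that the change is untested rather than any indication from the series.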

Compound 4, half-maximal inhibitory concentration: 75300 nM
For compound 4 the middle estimate is 1.9-fold (0.27 log units) below the measured one; measured number inside the range.
By their numbers in this assay, from the lowest: compounds 2, 1 and 4 (each within the scatter of the next, the first and the last beyond it); then compound 3.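

The phenoxy end of the shared core now has a measured change: in this assay, methoxy in place of hydrogen on an aromatic carbon, para to a large group, gives a 1.7-fold higher number from compound 1 to compound 4 (0.24 log units; within the scatter), so phenoxy and 4-methoxyphenoxy cannot be ordered at this position. One change at this end therefore leaves the number within the scatter, whereas replacing isopropyl with methyl on the saturated chain carbon gives a 4.8-fold higher number from compound 1 to compound 3 (0.68 log units; beyond the scatter), a step beyond it. No supporting measurement bears on why the methoxy change gives this result.

This single pair leaves open how other groups on the same aromatic carbon would read, such as fluorine, an amine, a carboxylic acid or a longer alkoxy chain. It also leaves open whether the methoxy step would stay within the scatter with the cyclohexyl of compound 2 or the methyl of compound 3 on the saturated chain carbon.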